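Metabolic stability of sulfonyl-amide variants on a shared core

The source may hold more compounds than are shown below. What is called first, only, known or untested is meant among the compounds shown, and "the series" means these compounds.

Measured so far in an ADME assay on microsomes from liver (Homo sapiens) for metabolic stability, with a stated time of 10 min; on this read-out lower numbers stand for a less stable compound and higher numbers for a more stable compound:
- compound 1 `O=C(NS(=O)(=O)c1ccc(F)cc1)c1ccc(Nc2nc(NC3(c4ccc(Cl)cc4)CC3)nc(OCC(F)(F)F)n2)cc1`: 100%
- compound 2 `CC(C)NC(=O)NCCS(=O)(=O)NC(=O)c1ccc(Nc2nc(NC3(c4ccc(Cl)cc4)CC3)nc(OCC(F)(F)F)n2)cc1`: 100%
- compound 3 `CNC(=O)NCCS(=O)(=O)NC(=O)c1ccc(Nc2nc(NC3(c4ccc(Cl)cc4)CC3)nc(OCC(F)(F)F)n2)cc1`: 97%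

Compound 3 sits within the scatter of both neighbours: a number 3 percentage points lower from compound 1 to compound 3 (within the scatter) and a number 3 percentage points lower from compound 2 to compound 3 (within the scatter), so the three numbers cannot be ordered against one another. Across the whole set the exchanges on the sulfonyl sulfur, no change at the digits printed from compound 1 to compound 2 (within the scatter) and a number 3 percentage points lower from compound 1 to compound 3 (within the scatter), changed nothing beyond the scatter in this assay, and the exchange on the amide-type nitrogen, a number 3 percentage points lower from compound 2 to compound 3 (within the scatter), did not either.

Compound 4 `NCCS(=O)(=O)NC(=O)c1ccc(Nc2nc(NC3(c4ccc(Cl)cc4)CC3)nc(OCC(F)(F)F)n2)cc1` follows from compound 3 by hydrogen in place of methylcarbamoyl on an amine nitrogen. The step that bears on it most directly is the one on the same nitrogen, a number 3 percentage points lower from compound 2 to compound 3 (within the scatter), and it was flat; the larger exchanges on the sulfonyl sulfur were flat as well. A step of a number 3 percentage points lower from compound 3 to compound 4 (within the scatter) in this assay is therefore expected for compound 4, meaning no change beyond the scatter. Compound 4 is estimated at 94%, with a range of 80% to 100%.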

Compound 4, percent of the compound remaining: 100%
Compound 4: the middle estimate sits 6 percentage points below what was measured; low and high end bracket the measured number.
By their numbers in this assay, from the lowest: compounds 3, 1, 2 and 4 (each within the scatter of the next).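

In this assay the methylcarbamoyl group can be cut back to hydrogen on the amine nitrogen with a number 3 percentage points higher from compound 3 to compound 4 (within the scatter) and the isopropylcarbamoyl group with no change at the digits printed from compound 2 to compound 4 (within the scatter) as the outcome, so the flat picture at this position extends beyond swapping one carbamoyl group for another to losing the carbamoyl group altogether. The bare 2-aminoethyl group on the sulfonyl sulfur also holds up against 4-fluorophenyl, with no change at the digits printed from compound 1 to compound 4 (within the scatter) as the step between them. No measurement available here explains why these exchanges leave the read-out flat.

Going by these compounds, whether a carboxylic acid, a tertiary amine or a longer chain on the sulfonyl sulfur would stay equally flat remains open. The shared core is identical in all four compounds, which leaves the effect of any exchange on it open too.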